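A few compounds are considered here, and "the series" means these few. Any claim that something is new, unique, unknown or untested is made for them only; others in the source may bear on it.

Measured so far in a functional assay on HCT-116 cells (Homo sapiens) for inhibition, read by luminescence and resazurin assay, with a stated time of 3 days; on this read-out lower numbers stand for stronger inhibition and higher numbers for weaker inhibition:
- compound 1 `CCNc1ncc(C)c(NCc2ccc(NC(=O)c3ccc(F)cc3)cc2)n1` gives only a limit of the assay, > 20000 nM
- compound 2 `CCNc1nc(NCc2ccc(C(=O)Nc3ccc(F)cc3)cc2)c2ccccc2n1` gives 1900 nM
- compound 3 `CCCNc1nc(NCc2ccc(C(=O)Nc3ccc(F)cc3)cc2)c2ccccc2n1` gives 1500 nM

The step from compound 3 to compound 2, (hydrogen in place of methyl on a saturated chain carbon, two bonds along the chain from a nitrogen on an aromatic ring), reads a 1.3-fold higher number from compound 3 to compound 2 (0.10 log units; within the scatter). Compound 4 `CNc1ncc(C)c(NCc2ccc(NC(=O)c3ccc(F)cc3)cc2)n1` is not yet measured; it differs from compound 1 by hydrogen in place of methyl on a saturated chain carbon bound to a nitrogen on an aromatic ring. The same kind of change is made here, though the place is not the same: in the measured pair it sits two bonds along the chain from a nitrogen on an aromatic ring, whereas in compound 4 it sits bound to that nitrogen. How the core of compound 1 differs from the core of compound 3 is not broken down here. Since compound 1 itself sits at the limit of > 20000 nM in this assay, at which 1 of the 3 values shown sits, the expected step that the limit leaves unreadable from compound 1 to compound 4 rests only on the small measured step, and compound 4 is expected to give 25000 nM, between 10000 nM and 60000 nM.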

Compound 4, half-maximal inhibitory concentration: > 20000 nM
Compound 4 gave a limit, no number; the forecaster's own chance of this, stated with the estimate: 85%; the middle value is on the limit's open side.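

In this assay compound 1 and compound 4 both give only a limit, and the step between them cannot be read. The compounds shown leave open whether changing ethylamino to methylamino on this core alters inhibition at all.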